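This account rests on a few compounds, and the source may have more. Where it says the series, first, only, none or still open, it means among the compounds named here.

Measured compounds:
Compound 1, `c1ccc(CNc2nnc(-c3ccc4cnccc4c3)o2)cc1`, in an ADME assay (liver) for metabolic stability, with Liver microsome (Rattus norvegicus) as the target, using microsomes (on this read-out lower numbers stand for slow clearance and higher numbers for fast clearance), gives 166 mL.min-1.g-1.
Compound 2, `Fc1cc2cc(-c3nnc(NCc4ccccc4)o3)ccc2cn1`, gives 56 mL.min-1.g-1.
Compound 3, `c1ccc([C@H](Nc2nnc(-c3c[nH]c4ncccc34)o2)C2CC2)cc1`, gives 31 mL.min-1.g-1.

Compound 2 differs from compound 1 by fluoro in place of hydrogen on an aromatic carbon, and this change gave a 3.0-fold lower number from compound 1 to compound 2 (0.47 log units; beyond the scatter). Compound 3 and compound 1 are built on different cores; the difference between the two cores is not broken down here. Compound 3 stands with the lowest number of the three, though its number and that of compound 2 lie within the scatter of each other.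

Compound 4, `Fc1ccccc1[C@H](Nc1nnc(-c2c[nH]c3ncccc23)o1)C1CC1`, is not yet measured. It differs from compound 3 by fluoro in place of hydrogen on an aromatic carbon. This is the same kind of change as that from compound 1 to compound 2, but not the same: in compound 2 the fluoro enters on a six-membered aromatic ring with one nitrogen, part of a fused system of two rings, next to the ring nitrogen, whereas in compound 4 it enters on a six-membered aromatic ring of carbon only, ortho to a large group. Because the earlier step of a 3.0-fold lower number from compound 1 to compound 2 (0.47 log units; beyond the scatter) pointed downward, compound 4 is expected to show a smaller step, a 1.3-fold lower number from compound 3 to compound 4 (0.11 log units; within the scatter), in this assay; the different surroundings of the fluoro make a direct transfer of its size uncertain. The estimate for compound 4 is 24 mL.min-1.g-1, between 10 mL.min-1.g-1 and 55 mL.min-1.g-1.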

Compound 4, intrinsic clearance in microsomes: 63 mL.min-1.g-1
Compound 4: the middle estimate sits 2.6-fold (0.42 log units) below what was measured; measured number above the stated range.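

In this assay, fluoro in place of hydrogen on an aromatic carbon gave a 2.0-fold higher number from compound 3 to compound 4 (0.31 log units; beyond the scatter), so the change ran the opposite way on the core of compound 3, and the two steps clearly differ: the same change on two cores in this assay, a 3.0-fold lower number (0.47 log units; beyond the scatter) from compound 1 to compound 2 and a 2.0-fold higher number (0.31 log units; beyond the scatter) from compound 3 to compound 4, 6.0-fold (0.78 log units) apart, beyond the scatter of two such steps. Within these compounds, then, neither the direction nor the size of the step carried over from one core to the other. This does not show why the steps part, since the two pairs differ in the core and also in the ring that takes the fluoro, and two pairs set no rule for the wider series.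

From the compounds shown here alone, it remains open whether fluoro on the core of compound 3 itself would give a lower number, as it did in compound 2. Also open, going by these compounds, is whether a chloro or a methoxy group on the same aromatic carbon of compound 3 would move the number as fluoro did in compound 4.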